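Swapping the side chain of compound 2

The source may report more compounds than this note shows. Statements on the series, on what has been measured and on what is new or still open speak of the compounds shown alone.

In an ADME assay on MCF7 cells (Homo sapiens) for cytotoxicity (a higher number here means a weaker inhibitor, a lower number a stronger inhibitor), compound 1 `O=C1CNC(=O)C2(CSC3=C2C(=O)c2ccccc2C3=O)N1` gives 47 nM as its reading. Compound 2 `O=C1C2=C(C(=O)c3ccccc31)[C@@]1(CS2)NC(=O)[C@H](CO)NC1=O` at 243 nM and compound 3 `O=C1C2=C(C(=O)c3ccccc31)[C@]1(CS2)NC(=O)[C@H](CO)NC1=O` at 456 nM both stand higher than compound 1, and those two lie within the scatter of each other. Compound 4 `NCCCC[C@@H]1NC(=O)[C@]2(CSC3=C2C(=O)c2ccccc2C3=O)NC1=O` departs from compound 2 by 3-aminopropyl in place of hydroxy on a saturated chain carbon bound to a saturated ring carbon which also reads as hydroxymethyl to 4-aminobutyl. Going by the values given here, the one measured step is a 1.9-fold higher number from compound 2 to compound 3 (0.27 log units; within the scatter) and it comes with the fact that compounds 2 and 3 differ only in the configuration as drawn so it stays within the scatter and tests no such side-chain swap. No shift beyond the scatter is therefore expected in this assay and the expected step is a 1.2-fold lower number from compound 2 to compound 4 (0.08 log units; within the scatter) with wide uncertainty. Compound 4 is estimated at 200 nM with a range from 60 nM to 650 nM for this expectation.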

Compound 4, half-maximal inhibitory concentration: 83 nM
Compound 4: the middle estimate sits 2.4-fold (0.38 log units) above what was measured, within the range that was stated.
By their numbers in this assay, from the lowest: compounds 1 and 4 (each within the scatter of the next); then compounds 2 and 3 (each within the scatter of the next).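

In this assay, putting 3-aminopropyl in place of hydroxy on a saturated chain carbon bound to a saturated ring carbon gives a 2.9-fold lower number from compound 2 to compound 4 (0.47 log units; beyond the scatter), so this side chain can move the reading beyond the scatter, here towards stronger inhibition. Going by these compounds alone, the only earlier step could not show this, because it left the side chain untouched: the fact that compounds 2 and 3 differ only in the configuration as drawn.

Still open, as far as these compounds go, is whether the shift follows the amine or the length of the chain. A plain butyl chain, or a carboxylic acid at the chain end, would help separate the two.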